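The source may report more compounds than this note shows. Statements on the series, on what has been measured and on what is new or still open speak of the compounds shown alone.

Measured compounds and their values:

Compound 1, `CC[C@@H]1C(=O)N(C)c2cnc(-n3ccc4cc(C(=O)NC)ccc43)nc2N1C1CCCC1`, in a functional assay on NCI-H1975 cells (Homo sapiens) for antiproliferative activity, read by CCK-8 assay, with a stated time of 72 h (on this read-out lower numbers stand for stronger inhibition of growth and higher numbers for weaker inhibition of growth), gives 1370 nM.
Compound 2, `CCCNC(=O)c1ccc2c(ccn2-c2ncc3c(n2)N(C2CCCC2)[C@H](CC)C(=O)N3C)c1`, gives 786 nM.
Compound 3, `CCCCNC(=O)c1ccc2c(ccn2-c2ncc3c(n2)N(c2ccn(C)n2)C(CC)C(=O)N3C)c1`, gives 12000 nM.

Compound 4, `CCNC(=O)c1ccc2c(ccn2-c2ncc3c(n2)N(c2ccn(C)n2)C(CC)C(=O)N3C)c1`, has not yet been measured in this assay.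

Compounds 1 and 2 share one core and differ only by hydrogen in place of ethyl on a saturated chain carbon bound to an amide-type nitrogen. The step this made is a 1.7-fold higher number from compound 2 to compound 1 (0.24 log units; within the scatter); the two values sit within the usual scatter of each other, so the data show no real movement from that change. Compound 3 carries a different core; the difference between the two cores is not broken down here. What the values show is that compound 3 gives the highest number of the three, beyond the scatter from both compound 1 and compound 2.

Compound 4 differs from compound 3 by hydrogen in place of ethyl on a saturated chain carbon, two bonds along the chain from an amide-type nitrogen. Among the measured compounds shown here, this is the same kind of change as the one from compound 2 to compound 1, but the place differs: there the ethyl left a saturated chain carbon bound to an amide-type nitrogen, here it leaves a saturated chain carbon two bonds along the chain from an amide-type nitrogen. Because the earlier step of a 1.7-fold higher number from compound 2 to compound 1 (0.24 log units; within the scatter) stayed within the scatter, a similarly small step is expected here. The step expected for compound 4 is a 1.3-fold higher number from compound 3 to compound 4 (0.10 log units; within the scatter). Compound 4 is therefore expected to give about 15000 nM in this assay, with a likely range from 6000 nM to 40000 nM.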

Compound 4, concentration for 50% growth inhibition: "not active" (no number reported)
For compound 4 the study gives words and no number; there is nothing to compare the estimate with.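

In this assay, among the compounds shown here, compound 4 is described in words as not active, with no number reported, and no step from compound 3 to compound 4 can be read. No measured evidence bearing on this result is available. The compounds shown leave open how far the change from butyl to ethyl moves growth inhibition when the rest of compound 3 stays the same.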